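A Basic Side Chain Returns to a Quinone Core

A few compounds are considered here, and "the series" means these few. Any claim that something is new, unique, unknown or untested is made for them only; others in the source may bear on it.

Compound 1 `O=C1c2c[n+]([O-])c3ccccc3c2C(=O)c2c1c1ccccc1n2Cc1cn(CC(O)CO)nn1` carries a 1-(2,3-dihydroxypropyl)-1H-1,2,3-triazol-4-yl group on a saturated chain carbon bound to an aromatic nitrogen. In a functional assay on SH-SY5Y cells (Homo sapiens) for cytotoxicity, read by MTT assay, with a stated time of 72 h (on this read-out higher numbers stand for weaker inhibition and lower numbers for stronger inhibition), compound 1 gives only a limit, > 1000 nM, and not a number, so it stands at the weak end of the values shown (the limit of > 1000 nM in this assay, at which 1 of the 3 values shown sits). Within the data shown here, compound 2 `CN1CCN(CCCCn2c3c(c4ccccc42)C(=O)c2c[n+]([O-])c4ccccc4c2C3=O)CC1` gives 100 nM in this assay, and the step of an at least 10-fold lower number from compound 1 to compound 2 (1.00 log units; beyond the scatter) is the one readable change from compound 1. Compound 3 `CCCN1CCN(CCCCn2c3c(c4ccccc42)C(=O)c2c[n+]([O-])c4ccccc4c2C3=O)CC1` gives 3970 nM; the step that the limit leaves unreadable from compound 1 to compound 3 cannot be sized, while a 40-fold higher number from compound 2 to compound 3 (1.60 log units; beyond the scatter) shows how sharply a small change on the ring amine moves the number.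

Compound 4 `O=C1c2c[n+]([O-])c3ccccc3c2C(=O)c2c1c1ccccc1n2CCCN1CCC(O)CC1` differs from compound 1 by 2-(4-hydroxypiperidin-1-yl)ethyl in place of 1-(2,3-dihydroxypropyl)-1H-1,2,3-triazol-4-yl on a saturated chain carbon bound to an aromatic nitrogen. The saturated ring amine on a three-carbon chain resembles compound 2 more than compound 3, so a drop similar to an at least 10-fold lower number from compound 1 to compound 2 (1.00 log units; beyond the scatter) is expected, tempered by the swing seen in a 40-fold higher number from compound 2 to compound 3 (1.60 log units; beyond the scatter). For compound 4 the expected value in this assay is 300 nM, within 60 nM to 2000 nM, an estimated step of an at least 3.3-fold lower number from compound 1 to compound 4 (0.52 log units; beyond the scatter).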

Compound 4, half-maximal inhibitory concentration: 130 nM
Compound 4: the middle estimate sits 2.3-fold (0.36 log units) above what was measured, within the range that was stated.
By their numbers in this assay, from the lowest: compounds 2 and 4 (each within the scatter of the next); then compound 3.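

Among these compounds, with an at least 7.6-fold lower number from compound 1 to compound 4 (0.88 log units; beyond the scatter) in this assay, 3-(4-hydroxypiperidin-1-yl)propyl is a second group, after the one in compound 2, that replaces (1-(2,3-dihydroxypropyl)-1H-1,2,3-triazol-4-yl)methyl and gives a clearly lower number. The step of a 1.3-fold higher number from compound 2 to compound 4 (0.11 log units; within the scatter) cannot separate these two groups, whereas a 31-fold lower number from compound 3 to compound 4 (1.48 log units; beyond the scatter) sets compound 4 well apart from the propyl piperazine, so a piperazine is not required for a number in this range. Compound 1 remains a limit, so the first of these steps has no exact size: the limit of > 1000 nM in this assay, at which 1 of the 4 values shown sits.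

The compounds shown leave open whether a morpholine or an unsubstituted piperidine on the same propyl chain would match compound 4. They also leave open whether an ethyl group on the piperazine would give a number nearer that of compound 2 or compound 3.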